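Thiocarbonyl aryl series: from compound 2 to compound 3

This account rests on a few compounds, and the source may have more. Where it says the series, first, only, none or still open, it means among the compounds named here.

In a functional assay on HeLa cells (Homo sapiens) for antiproliferative activity, read by sulforhodamine B assay, with a stated time of 72 h (a higher number here means a weaker inhibitor, a lower number a stronger inhibitor), compound 1 (`Cc1cccc(NC(=S)N/N=C/c2ccc3ccccc3n2)c1`) gives > 100000 nM, which is a limit of the assay and not a number. Compound 2 (`Cc1ccccc1NC(=S)N/N=C/c1ccc2ccccc2n1`) gives > 100000 nM, also a limit and not a number. Among the measured compounds shown here, the only measured step is a step that the two limits leave unreadable from compound 1 to compound 2, which places 2-methylphenyl where 3-methylphenyl stood. The whole record so far is the limit of > 100000 nM in this assay, at which 2 of the 2 values shown sit. Compound 2 therefore has no numerical position in the series.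

Compound 3 (`S=C(N/N=C/c1ccc2ccccc2n1)Nc1ccc(Br)cc1`) carries 4-bromophenyl in place of 2-methylphenyl on an amide-type nitrogen whose other neighbour is the thiocarbonyl carbon: 4-bromophenyl in place of 2-methylphenyl on an amide-type nitrogen. For the measured compounds named here, no measured step involves this exchange, and the one step available gives no size to carry over. In this assay, no step beyond the scatter is therefore expected, and no direction can be assigned with confidence. Another limit is the likeliest result, although a measurable value cannot be excluded. The estimated change is a number no higher from compound 2 to compound 3 (the limit leaves the size open). For compound 3, the expected value is 100000 nM, with an estimated range of 20000 nM to 200000 nM.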

Compound 3, half-maximal inhibitory concentration: 56800 nM
Compound 3: the middle estimate sits 1.8-fold (0.25 log units) above what was measured; the measured number falls inside the stated range.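

In this assay, among the compounds shown here, compound 3 gives 56800 nM, the only number so far, so a change on the amide-type nitrogen whose other neighbour is the thiocarbonyl carbon can yield a measured number. Placing 4-bromophenyl there in place of 2-methylphenyl gives an at least 1.7-fold lower number from compound 2 to compound 3 (0.24 log units; that floor lies within the scatter), and placing it there in place of 3-methylphenyl gives an at least 1.7-fold lower number from compound 1 to compound 3 (0.24 log units; that floor lies within the scatter); both are floors that do not clear the scatter, so neither shows a real change in size, and the step between the two methylphenyl compounds cannot be read. Both floors rest on the limits of the two methylphenyl compounds, which are limits and not numbers: the limit of > 100000 nM in this assay, at which 2 of the 3 values shown sit.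

The compounds shown leave open whether the bromine or the place of the group on the phenyl ring goes with the measurable value, as no bromophenyl and methylphenyl pair here shares a place. They also leave open how an amine or a carboxylic acid on that phenyl ring would read, and how a carbonyl would read in place of the thiocarbonyl.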